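The source may report more compounds than this note shows. Statements on the series, on what has been measured and on what is new or still open speak of the compounds shown alone.

Notes on the series in a functional assay on HUVEC cells (Homo sapiens) for inhibition (a higher number here means a weaker inhibitor, a lower number a stronger inhibitor), follow. Compound 1 `CN(c1ccc(NC(=O)Nc2ccccc2)cc1)c1ccnc(Nc2cccc(CS(C)(=O)=O)c2)n1` gives 0.2 nM here, compound 2 `CC(=O)c1ccc(NC(=O)Nc2ccc(N(C)c3ccnc(Nc4cccc(CS(C)(=O)=O)c4)n3)cc2)cc1` gives 2 nM here, and compound 3 `CN(c1ccc(NC(=O)Nc2c(Cl)cccc2Cl)cc1)c1ccnc(Nc2cccc(CS(C)(=O)=O)c2)n1` stands highest of the three at 29 nM so far. Compound 4 `CCCCNC(=O)Nc1ccc(N(C)c2ccnc(Nc3cccc(CS(C)(=O)=O)c3)n2)cc1` differs from compound 3 by one change, butyl in place of 2,6-dichlorophenyl on an amide-type nitrogen. Two measured steps change this same place (a 150-fold higher number from compound 1 to compound 3 (2.16 log units; beyond the scatter); a 15-fold higher number from compound 2 to compound 3 (1.16 log units; beyond the scatter)), both large, and each ends on 2,6-dichlorophenyl. Among the compounds with values here, no butyl compound has been measured, so these steps guide direction more than size. A moderate step is expected in this assay, toward a lower number and smaller than either of those two (a 4.8-fold lower number from compound 3 to compound 4 (0.68 log units; beyond the scatter)). The estimate for compound 4 is an expected 6 nM (range 1 nM to 30 nM).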

Compound 4, half-maximal inhibitory concentration: 2 nM
Compound 4: the middle estimate sits 3.0-fold (0.48 log units) above what was measured, within the range that was stated.
By their numbers in this assay, from the lowest: compound 1; then compounds 2 and 4 (each within the scatter of the next); then compound 3.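

In this assay, a ring on the amide-type nitrogen is not required for a low number: butyl, which has no ring, gives a 15-fold lower number from compound 3 to compound 4 (1.16 log units; beyond the scatter), and no change at the digits printed from compound 2 to compound 4 (within the scatter). Phenyl nevertheless remains preferable to butyl at this place, with a 10-fold higher number from compound 1 to compound 4 (1.00 log units; beyond the scatter). No available evidence accounts for these differences.

Going by these compounds, it remains open how the number responds to chain length and branching, as in a hexyl or tert-butyl group. A butyl chain ending in an amine or a carboxylic acid is also an open case.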